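This account rests on a few compounds, and the source may have more. Where it says the series, first, only, none or still open, it means among the compounds named here.

Measured so far:

- compound 1 `COc1ccc(/C=N/c2c(C)n(C)n(-c3ccccc3)c2=O)cc1`: 186000000 nM
- compound 2 `COc1ccc(/C=N/c2c(C)n(C)n(-c3ccccc3)c2=O)cc1OC`: 141000000 nM

For the measured compounds named here, in a functional assay on P388 cells (Mus musculus) for cytotoxicity, read by MTT assay, with a stated time of 72 h (a higher number here means a weaker inhibitor, a lower number a stronger inhibitor), compound 1 gives the highest of the two numbers; the only neighbour is compound 2, and the step of a 1.3-fold lower number from compound 1 to compound 2 (0.12 log units; within the scatter) falls within the scatter, so the two values cannot be ranked. Compound 3 `COc1ccccc1/C=N/c1c(C)n(C)n(-c2ccccc2)c1=O` is still to be measured. It differs from compound 1 by 2-methoxyphenyl in place of 4-methoxyphenyl on a carbon with a double bond to nitrogen. Going by the values given here, no measured step moves the methoxy group around the aromatic ring; the one step available, from compound 1 to compound 2, adds a second methoxy and changes nothing beyond the scatter. Both measured values sit at a very high concentration, and nothing among them suggests that rearranging the same atoms would move the number far. The expectation for compound 3 is therefore a value close to compound 1, with an estimated step of a 1.0-fold lower number from compound 1 to compound 3 (0.01 log units; within the scatter). Compound 3 is estimated at 180000000 nM, within 60000000 nM to 540000000 nM.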

Compound 3, half-maximal inhibitory concentration: 229000000 nM
Estimate against measurement, compound 3: 1.3-fold (0.10 log units) below, and the stated range covers the measured number.
By their numbers in this assay, from the lowest: compounds 2, 1 and 3 (each within the scatter of the next).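

Moving the methoxy group, with 2-methoxyphenyl in place of 4-methoxyphenyl on a carbon with a double bond to nitrogen, gives in this assay a 1.2-fold higher number from compound 1 to compound 3 (0.09 log units; within the scatter) and so does not separate compound 1 from compound 3. Where the step from compound 1 to compound 2 added a methoxy group, this one keeps the same atoms and tests only their placement, and the two placements compared here cannot be told apart. No available evidence bears on the reason for this result.

As far as these compounds go, whether an amine or a carboxylic acid in place of the methoxy group on this aromatic ring would give a step beyond the scatter remains open. The same holds for a longer chain such as butoxy in place of methoxy.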